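A few compounds are considered here, and "the series" means these few. Any claim that something is new, unique, unknown or untested is made for them only; others in the source may bear on it.

Within the data shown here, in a functional assay on MGC-803 cells (Homo sapiens) for inhibition, read by sulforhodamine B assay (a lower number here means a stronger inhibitor, a higher number a weaker inhibitor), two compounds built on one shared core have numbers so far. Compound 1 `O=C1C=C(NCc2ccccc2)C(=O)c2c1nc1n2[C@H]2OC[C@@H](O)[C@H]2OC1`, with a benzyl group on an amine nitrogen, gives 2670 nM. Compound 2 `O=C1C=C(Nc2cccc(F)c2)C(=O)c2c1nc1n2[C@H]2OC[C@@H](O)[C@H]2OC1`, with 3-fluorophenyl on that nitrogen, gives 2180 nM, so compound 2 stands level with compound 1 within the usual scatter of repeated measurements.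

The unmeasured compound 3 `O=C1C=C(NC2CCCC2)C(=O)c2c1nc1n2[C@H]2OC[C@@H](O)[C@H]2OC1` differs from compound 2 at that same place: cyclopentyl in place of 3-fluorophenyl on an amine nitrogen. Put simply, cyclopentyl sits in place of 3-fluorophenyl on an amine nitrogen. Among the measured compounds shown here, only one measured step bears on this change: 3-fluorophenyl in place of benzyl on an amine nitrogen gave a 1.2-fold lower number from compound 1 to compound 2 (0.09 log units; within the scatter), which is within the scatter. That is thin evidence, and neither measured compound carries a non-aromatic ring directly on this nitrogen. Even so, no step beyond the scatter is expected in this assay, and neither direction is favoured. The estimated step is a 1.1-fold higher number from compound 2 to compound 3 (0.06 log units; within the scatter). Compound 3 is expected to give about 2500 nM, with an estimated range of 900 nM to 7000 nM.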

Compound 3, half-maximal inhibitory concentration: > 8000 nM
Compound 3 ended at the assay's limit; the forecaster's own chance of this, stated with the estimate: 5%; middle value at least 3.2-fold (0.50 log units) away from the limit.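

The change at this amine nitrogen turns out not to be neutral in this assay. Benzyl and 3-fluorophenyl stood level, yet cyclopentylamino in place of (3-fluorophenyl)amino brings an at least 3.6-fold higher number from compound 2 to compound 3 (0.56 log units; beyond the scatter) on the shared core, and cyclopentyl in place of benzyl brings an at least 2.9-fold higher number from compound 1 to compound 3 (0.47 log units; beyond the scatter) as well. Among these three compounds, then, the two groups holding a six-membered aromatic ring stay together while the one holding a five-membered non-aromatic ring gives the weaker result, and compound 3 goes with neither of the others; its number is a limit and not an exact value, so the true size of both steps stays unknown: the limit of > 8000 nM in this assay, at which 1 of the 3 values shown sits.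

Going by these compounds, three compounds cannot separate the loss of the aromatic ring from the change in ring size or the loss of the fluorine, so it remains open which of these matters. Phenyl without fluorine, cyclohexyl, or an open chain such as butyl on this nitrogen would each test one of those differences, and any of them could stay level with compound 2 or fall away as compound 3 does.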